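Return of an Aryl Amine on the Shared Core

This account rests on a few compounds, and the source may have more. Where it says the series, first, only, none or still open, it means among the compounds named here.

Compound 2 `Cc1cc(NCCO)nc(SCc2nc3ccccc3[nH]2)n1` gives > 100000 nM in a functional assay on ECa-109 cells (Homo sapiens) for cytotoxicity, read by MTT assay, with a stated time of 72 h (a higher number here means a weaker inhibitor, a lower number a stronger inhibitor), which is a limit of the assay the limit of > 100000 nM in this assay, at which 1 of the 2 values shown sits, rather than a number. In this assay compound 1 `COc1ccc(Nc2cc(C)nc(SCc3nc4ccccc4[nH]3)n2)cc1` gives 69800 nM. Within the data shown here, the one measured step, an at least 1.4-fold higher number from compound 1 to compound 2 (0.15 log units; that floor lies within the scatter), stays within the scatter.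

Compound 3 `COc1ccccc1Nc1cc(C)nc(SCc2nc3ccccc3[nH]2)n1` differs from compound 2 by 2-methoxyphenyl in place of 2-hydroxyethyl on a nitrogen on an aromatic ring. Among the measured compounds shown here, only that single step bears on this change, and it ran the other way with no size beyond the scatter. For compound 3 the expected step is therefore an at least 1.4-fold lower number from compound 2 to compound 3 (0.15 log units; that floor lies within the scatter), a return toward where compound 1 stands at 69800 nM. Compound 3 is estimated at 70000 nM, expected between 25000 nM and 200000 nM.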

Compound 3, half-maximal inhibitory concentration: 34400 nM
Compound 3: middle estimate off by 2.0-fold (0.31 log units), on the high side; measured number inside the range.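

In this assay, among these compounds, the change from 2-hydroxyethyl to 2-methoxyphenyl gives an at least 2.9-fold lower number from compound 2 to compound 3 (0.46 log units; beyond the scatter) and is the first step on this nitrogen to clear the scatter. The two aryl amines also part: 2-methoxyphenyl in place of 4-methoxyphenyl gives a 2.0-fold lower number from compound 1 to compound 3 (0.31 log units; beyond the scatter) and shows that where the methoxy sits on the phenyl ring counts in this assay. Compound 2 stands at a limit of the assay, and the step from it is only a floor: the limit of > 100000 nM in this assay, at which 1 of the 3 values shown sits.

On these data alone, what a plain phenyl, a 3-methoxyphenyl or a 2-chlorophenyl group on this nitrogen would give remains open.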